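Swapping tert-butyl for 1H-pyrazol-1-yl in the series

The compounds below may be only part of what the source reports. "The series", "measured", "known", "first", "only" and "open" are said of these compounds alone.

In an ADME assay on Caco-2 cells (Homo sapiens) for permeability, read by LC-MS, in the apical to basolateral direction, with a stated time of 60 min, at pH 6.5 (on this read-out higher numbers stand for higher permeability and lower numbers for lower permeability), compound 1 `CC1(C[C@@H](O)C(=O)N2N=CC[C@H]2C(=O)NCc2cc(Cl)ccc2-n2cnnn2)CC1` gives 9.5 10^-6 cm/s and compound 2 `CC(C)(C)C[C@@H](O)C(=O)N1C[C@@H]2C[C@@H]2[C@H]1C(=O)NCc1cc(Cl)ccc1-n1cnnn1` gives 25 10^-6 cm/s as the higher number, a gap beyond the usual scatter. Compared with compound 2, compound 3 `O=C(NCc1cc(Cl)ccc1-n1cnnn1)[C@@H]1[C@H]2C[C@H]2CN1C(=O)[C@H](O)Cn1cccn1` carries 1H-pyrazol-1-yl in place of tert-butyl on a saturated chain carbon, two bonds along the chain from a carbonyl carbon and an oxygen on a saturated carbon, counted as 1H-pyrazol-1-yl in place of tert-butyl on a saturated chain carbon, two bonds along the chain from a carbonyl carbon and an oxygen on a saturated carbon in this swap. Going by the values given here, no measured pair isolates this change. A drop beyond the scatter is expected on the structural change alone, with a 6.3-fold lower number from compound 2 to compound 3 (0.80 log units; beyond the scatter) as the estimated step in this assay here. For compound 3 the expected value is 4 10^-6 cm/s with an estimated range of 1.2 10^-6 cm/s to 12 10^-6 cm/s around it.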

Compound 3, apparent permeability: 0.31 10^-6 cm/s
Beside the measured number, compound 3's estimate is 13-fold (1.11 log units) above it; the measured number lies below the stated range.
By their numbers in this assay, from the lowest: compound 3; then compound 1; then compound 2.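

At this place, on a saturated chain carbon, two bonds along the chain from a carbonyl carbon and an oxygen on a saturated carbon, the series now has its first change in one place. 1H-pyrazol-1-yl in place of tert-butyl gives an 81-fold lower number from compound 2 to compound 3 (1.91 log units; beyond the scatter) in this assay and the step is large, so this position is not indifferent to the swap. No supporting measurement accompanies this step to account for it.

As far as these compounds go, whether a cyclopentyl or a primary amine here would read closer to compound 2 or to compound 3 stays open. So does whether the same swap on the core of compound 1 gives a step of similar size.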